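The compounds below may be only part of what the source reports. "The series", "measured", "known", "first", "only" and "open" are said of these compounds alone.

Working notes on the series. The two measured compounds share one core: compound 1 is `COc1ccc(/C=C/C(=O)OC[C@H]2O[C@@H](O[C@H]3OC=C[C@@]4(O)[C@@H]3[C@](C)(O)C[C@@H]4O)[C@H](O)[C@@H](O)[C@@H]2O)cc1OC` and compound 2 is `COc1ccc(/C=C/C(=O)OC[C@H]2O[C@@H](O[C@H]3OC=C[C@@]4(O)[C@@H]3[C@](C)(O)C[C@@H]4O)[C@H](O[C@@H]3O[C@H](CO)[C@@H](O)[C@H](O)[C@H]3O)[C@@H](O)[C@@H]2O)cc1`. In a functional assay for inhibition, with a stated time of 60 min (a lower number here means a stronger inhibitor, a higher number a weaker inhibitor), compound 1 gives 33100 nM; in this assay compound 2 gives 39000 nM. Compound 2 and compound 1 lie within the scatter of each other, so the two numbers say the same thing: weak inhibition across the pair. Compound 3, `COc1ccc(/C=C/C(=O)OC[C@H]2O[C@@H](O[C@H]3OC=C[C@@]4(O)[C@@H]3[C@](C)(O)C[C@@H]4O)[C@H](O)[C@@H](O)[C@@H]2O)cc1`, is not yet measured. Against compound 2 it differs in one place, (hydrogen in place of 3,4,5-trihydroxy-6-(hydroxymethyl)oxan-2-yl on an oxygen on a saturated carbon), the same difference cut one bond further out reading as (3,4,5-trihydroxy-6-(hydroxymethyl)oxan-2-yl)oxy to hydroxy. Among the measured compounds shown here, no measured pair isolates this change, so the step is estimated rather than read off; the expected step from compound 2 to compound 3 is a 1.1-fold lower number from compound 2 to compound 3 (0.03 log units; within the scatter), which is taken as none beyond the scatter. Compound 3 is therefore expected to give about 36000 nM, with a range from 15000 nM to 85000 nM.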

Compound 3, half-maximal inhibitory concentration: 67300 nM
Compound 3: middle estimate off by 1.9-fold (0.27 log units), on the low side; low and high end bracket the measured number.
By their numbers in this assay, from the lowest: compounds 1, 2 and 3 (each within the scatter of the next, the first and the last beyond it).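

In this assay, hydrogen in place of 3,4,5-trihydroxy-6-(hydroxymethyl)oxan-2-yl on an oxygen on a saturated carbon gives a 1.7-fold higher number from compound 2 to compound 3 (0.24 log units; within the scatter), so in this pair that large group can be cut back to hydroxy without a change beyond the scatter. Hydrogen in place of methoxy on an aromatic carbon gives a 2.0-fold higher number from compound 1 to compound 3 (0.31 log units; beyond the scatter), a modest step and the first sign that this aromatic position has any bearing on the read-out. No measurement at hand accounts for either step.

Going by these compounds, whether an amine or a carboxylic acid on that aromatic carbon, or a longer chain such as ethoxy, would give a larger step remains open. Also open, on these data alone, is whether removing the 3,4,5-trihydroxy-6-(hydroxymethyl)oxan-2-yl group gives a similar step with the methoxy present.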